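The source may report more compounds than this note shows. Statements on the series, on what has been measured and on what is new or still open speak of the compounds shown alone.

Measured so far in a functional assay on HeLa cells (Homo sapiens) for cytotoxicity, read by MTT assay, with a stated time of 72 h; a lower number here means a stronger inhibitor, a higher number a weaker inhibitor:
compound 1 `NS(=O)(=O)c1cc(-c2nnc(CN3CCN(Cc4ccccc4)CC3)o2)c(Cl)cc1SCc1ccccc1` gives 17000 nM
compound 2 `[N-]=[N+]=NCc1nnc(-c2cc(S(N)(=O)=O)c(SCc3ccccc3)cc2Cl)o1` gives 115000 nM
compound 3 `COc1ccc(-c2cn(Cc3nnc(-c4cc(S(N)(=O)=O)c(SCc5ccccc5)cc4Cl)o3)nn2)cc1` gives 68000 nM

Compound 2 carries the highest of the three numbers. Compound 3 stands nearest to it, and the gap between the two lies within the scatter, so no order between compound 2 and compound 3 is claimed. Compound 1 stands furthest from compound 2, with a lower number, and that gap lies beyond the scatter.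

Compound 4 `NCc1nnc(-c2cc(S(N)(=O)=O)c(SCc3ccccc3)cc2Cl)o1` has not yet been measured in this assay. It differs from compound 2 in one place: amino in place of azido on a saturated chain carbon bound to an aromatic carbon. For the measured compounds named here, no step between two measured compounds covers this change, so the expectation rests on the series as a whole, in which all three numbers are high and the only gap beyond the scatter accompanies a far larger structural change than the one here. For compound 4 a small step is expected, toward a somewhat lower number and not clearly beyond the scatter: a 1.4-fold lower number from compound 2 to compound 4 (0.16 log units; within the scatter). Compound 4 is estimated at 80000 nM, with a range from 25000 nM to 250000 nM.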

Compound 4, half-maximal inhibitory concentration: 490000 nM
Beside the measured number, compound 4's estimate is 6.1-fold (0.79 log units) below it; measured number above the stated range.
By their numbers in this assay, from the lowest: compound 1; then compounds 3 and 2 (each within the scatter of the next); then compound 4.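

For the compounds shown here, on the saturated chain carbon bound to an aromatic carbon, amino in place of azido gives the first step that can be read as a single change: in this assay, the result is a 4.3-fold higher number from compound 2 to compound 4 (0.63 log units; beyond the scatter). The position is therefore not indifferent to the group it carries, and this change moves toward weaker inhibition, not toward the stronger inhibition that a shift to the amino group might have suggested. Nothing measured here accounts for the size or direction of this step.

One pair cannot show whether the step belongs to the amino group itself or to the departure of azido; a dimethylamino group, a hydroxyl or an acetamide on the same carbon would help separate the two. Also open, as far as these compounds go, is whether the step would persist with a longer chain, such as aminoethyl.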